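Methoxy to Bromo in a Narrow Range of Values

The compounds below may be only part of what the source reports. "The series", "measured", "known", "first", "only" and "open" are said of these compounds alone.

In an ADME assay on L6 cells (Rattus norvegicus) for cytotoxicity, read by resazurin assay, with a stated time of 72 h (a lower number here means a stronger inhibitor, a higher number a weaker inhibitor), compound 1 `OC(c1ccc(Cl)cc1)(c1ccc(Br)cc1)c1cccnc1` gives 57000 nM, compound 2 `Cc1ccccc1C(O)(c1ccc(Cl)cc1)c1cccnc1` gives 82000 nM and compound 3 `COc1cccc(C(O)(c2ccc(Cl)cc2)c2cccnc2)c1` gives 85600 nM. Compound 3 thus lies within the scatter of both others. Within the data shown here, the only measured step, a 1.4-fold higher number from compound 1 to compound 2 (0.16 log units; within the scatter), shows little movement when one aromatic group replaces another. Compound 4 `OC(c1ccc(Cl)cc1)(c1cccnc1)c1cccc(Br)c1` differs from compound 3 by bromo in place of methoxy on an aromatic carbon, with bromo in place of methoxy on an aromatic carbon. Compound 1, which also carries a bromo group, gives 57000 nM, so no step beyond the scatter is expected in this assay. The expected change is a 1.2-fold lower number from compound 3 to compound 4 (0.09 log units; within the scatter). For compound 4 the estimated value is 70000 nM, with an expected range from 40000 nM to 120000 nM.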

Compound 4, half-maximal inhibitory concentration: 54100 nM
The estimate for compound 4 lay 1.3-fold (0.11 log units) above the measured number; the range from low to high includes it.
By their numbers in this assay, from the lowest: compounds 4, 1, 2 and 3 (each within the scatter of the next).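

In this assay, bromo in place of methoxy on this aromatic carbon gives a 1.6-fold lower number from compound 3 to compound 4 (0.20 log units; within the scatter), so the two groups cannot be told apart here. The other two comparisons agree: 3-bromophenyl in place of 4-bromophenyl gives a 1.1-fold lower number from compound 1 to compound 4 (0.02 log units; within the scatter), and 3-bromophenyl in place of 2-methylphenyl gives a 1.5-fold lower number from compound 2 to compound 4 (0.18 log units; within the scatter), so all four compounds sit within a narrow band. No outside evidence bears on why these numbers stay so close. From the compounds shown here alone, whether an amine, a carboxylic acid or a longer chain on this aromatic ring would produce a step beyond the scatter remains open.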